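This account rests on a few compounds, and the source may have more. Where it says the series, first, only, none or still open, it means among the compounds named here.

Measured compounds:
compound 1, `COc1ccc(-c2sc(N(C)C)nc2-c2cc(OC)c(OC)c(OC)c2)cc1`: 3370 nM
compound 2, `CCOc1ccc(-c2sc(N(C)C)nc2-c2cc(OC)c(OC)c(OC)c2)cc1`: 3260 nM
compound 3, `COc1ccc(-c2sc(C)nc2-c2cc(OC)c(OC)c(OC)c2)cc1`: 500 nM

All three were run in a functional assay on HeLa cells (Homo sapiens) for antiproliferative activity, read by MTT assay, with a stated time of 72 h; on this read-out lower numbers stand for stronger inhibition and higher numbers for weaker inhibition. The change methyl in place of hydrogen on a saturated chain carbon bound to an oxygen on an aromatic ring gave a 1.0-fold lower number from compound 1 to compound 2 (0.01 log units; within the scatter). The cores of compound 1 and compound 3 differ by methyl in place of dimethylamino on an aromatic carbon, and that step gave a 6.7-fold lower number from compound 1 to compound 3 (0.83 log units; beyond the scatter). Compound 3 therefore holds the lowest number of the three, with both other compounds beyond the scatter from it.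

Compound 4, `CCOc1ccc(-c2sc(C)nc2-c2cc(OC)c(OC)c(OC)c2)cc1`, has not yet been run in this assay. It differs from compound 3 by methyl in place of hydrogen on a saturated chain carbon bound to an oxygen on an aromatic ring, which is the same change as from compound 1 to compound 2: the place lines read alike, word for word. On that pair the change moved the number by only a 1.0-fold lower number from compound 1 to compound 2 (0.01 log units; within the scatter). With one instance to go on, the step from compound 3 to compound 4 is expected to be about a 1.0-fold higher number from compound 3 to compound 4 (0.02 log units; within the scatter) in this assay, which rests on compound 1 and compound 2 showing no change beyond the scatter. Compound 4 is accordingly estimated at 520 nM, with a range from 250 nM to 1100 nM.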

Compound 4, half-maximal inhibitory concentration: 1870 nM
The estimate for compound 4 lay 3.6-fold (0.56 log units) below the measured number; the measured number lies above the stated range.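

In this assay, the change from methoxy to ethoxy gave a 3.7-fold higher number from compound 3 to compound 4 (0.57 log units; beyond the scatter), so on this core it does not behave as it did on the core of compound 1, and the two results do not agree: the same change on two cores in this assay, a 1.0-fold lower number (0.01 log units; within the scatter) from compound 1 to compound 2 and a 3.7-fold higher number (0.57 log units; beyond the scatter) from compound 3 to compound 4, 3.9-fold (0.59 log units) apart, beyond the scatter of two such steps. The change of dimethylamino to methyl, read on the ethoxy compounds, gave a 1.7-fold lower number from compound 2 to compound 4 (0.24 log units; within the scatter), and it too depends on its partner: the same change on two cores in this assay, a 6.7-fold lower number (0.83 log units; beyond the scatter) from compound 1 to compound 3 and a 1.7-fold lower number (0.24 log units; within the scatter) from compound 2 to compound 4, 3.9-fold (0.59 log units) apart, beyond the scatter of two such steps. These four compounds show that neither change can be carried from one core to the other as a fixed step, but with a single pair per core they do not show why the steps differ, or which of the two results would be more typical of further cores.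

A longer chain, such as propoxy, in place of ethoxy on either core would show whether the step seen on the core of compound 3 continues or levels off. A primary amine or an ethyl group in place of methyl or dimethylamino would show whether the dependence seen here extends beyond these two groups.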